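A few compounds are considered here, and "the series" means these few. Any claim that something is new, unique, unknown or untested is made for them only; others in the source may bear on it.

Working notes on the series. Compound 1 `CCCCCc1cc(C)c(C(=O)N=C(N)N)cc1S(C)(=O)=O` gives 27 nM in a functional assay for inhibition of sodium/hydrogen exchanger (Oryctolagus cuniculus); a lower number here means a stronger inhibitor, a higher number a weaker inhibitor. Compound 2 `CCCSc1cc(C)c(C(=O)N=C(N)N)cc1S(C)(=O)=O` gives 6.8 nM in this assay, and the step of a 4.0-fold lower number from compound 1 to compound 2 (0.60 log units; beyond the scatter). Compound 3 `Cc1cc(Sc2ccccc2Cl)c(S(C)(=O)=O)cc1C(=O)N=C(N)N` gives 14 nM in this assay, the second highest of the three numbers shown; the step of a 1.9-fold lower number from compound 1 to compound 3 (0.29 log units; within the scatter), while the step of a 2.1-fold higher number from compound 2 to compound 3 (0.31 log units; beyond the scatter). Compound 4 `Cc1cc(Sc2ccccc2)c(S(C)(=O)=O)cc1C(=O)N=C(N)N` differs from compound 3 by hydrogen in place of chloro on an aromatic carbon. Among the measured compounds shown here, no measured step in this set removes a substituent from the ring of the (2-chlorophenyl)sulfanyl group. The two steps that touch this part of the molecule, from compound 1 to compound 3 and from compound 2 to compound 3, exchange the whole group rather than a single atom on it and were at most modest in size, so only a shift within the scatter of this assay, in no set direction, is expected here. Compound 4 is therefore estimated at 16 nM in this assay, with a range from 7 nM to 35 nM. The expected step is a 1.1-fold higher number from compound 3 to compound 4 (0.06 log units; within the scatter).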

Compound 4, half-maximal inhibitory concentration: 14 nM
Compound 4: the middle estimate sits 1.1-fold (0.06 log units) above what was measured, and the stated range covers the measured number.
By their numbers in this assay, from the lowest: compound 2; then compounds 3, 4 and 1 (each within the scatter of the next).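

In this assay, hydrogen in place of chloro on an aromatic carbon, ortho to a large group, gives no change at the digits printed from compound 3 to compound 4 (within the scatter), so this single-atom change at this position can be read directly and the chloro is not needed to hold the number. Phenyl in place of propyl on a sulfur gives a 2.1-fold higher number from compound 2 to compound 4 (0.31 log units; beyond the scatter), and exchanging the pentyl group for the phenylsulfanyl group gives a 1.9-fold lower number from compound 1 to compound 4 (0.29 log units; within the scatter), so the unsubstituted phenylsulfanyl group stands against both alkyl compounds much as the (2-chlorophenyl)sulfanyl group does. No data here offer a reason for this result.

From the compounds shown here alone, whether a methoxy group or an amine in place of the chloro would also leave the number unmoved remains open. So does whether a chain longer than propyl on the sulfur would keep the number of compound 2.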